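Swapping a Dialkylamino Chain for a Bromobenzyl Amine

The compounds below may be only part of what the source reports. "The series", "measured", "known", "first", "only" and "open" are said of these compounds alone.

Measured compounds:
Compound 1, `CN(C)CCN(CCN(C)C)c1ccc(C(=O)N2CCc3ccc(OS(N)(=O)=O)cc3C2)cc1`: 1.93
Compound 2, `NS(=O)(=O)Oc1ccc2c(c1)CN(C(=O)c1ccc(N3CCN(Cc4ccccc4)CC3)cc1)CC2`: 1.93

Compound 1 and compound 2 share the same core and were both read out in a physicochemical assay for lipophilicity; on this read-out lower numbers stand for lower lipophilicity and higher numbers for higher lipophilicity. In this assay compound 1 gives 1.93, and compound 2 gives 1.93; the two stand level at the digits shown, within the scatter of repeated measurements, so no order between them can be stated.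

Compound 3, `CCN(Cc1ccc(Br)cc1)c1ccc(C(=O)N2CCc3ccc(OS(N)(=O)=O)cc3C2)cc1`, has not yet been measured. It differs from compound 1 in one place: (4-bromobenzyl)(ethyl)amino in place of bis(2-(dimethylamino)ethyl)amino on an aromatic carbon. For the measured compounds named here, no step between two measured compounds covers this kind of change, so no measured step can be leaned on.

An increase beyond the scatter is expected, with the step from compound 1 to compound 3 estimated at a number 1.67 log units higher from compound 1 to compound 3 (beyond the scatter). For compound 3 the expected value in this assay is 3.6, with a range from 2.9 to 4.3.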

Compound 3, partition coefficient: 1.93
Compound 3: the middle estimate sits 1.67 log units above what was measured, outside the stated range (below it).
By their numbers in this assay, from the lowest: compounds 1, 2 and 3 (each within the scatter of the next).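

In this assay, putting (4-bromobenzyl)(ethyl)amino in place of bis(2-(dimethylamino)ethyl)amino on this aromatic carbon gives no change at the digits printed from compound 1 to compound 3 (within the scatter). The change is not a small one in make-up: a group with three nitrogens and no ring leaves, and one with a single nitrogen, a bromine and a six-membered aromatic ring of carbon only enters. At this position, then, a swap of that extent leaves the read-out level. Nothing available accounts for this outcome.

The compounds shown leave open whether the read-out also stays level with other groups on this aromatic carbon, such as a carboxylic acid or a longer alkyl chain. They also leave open what a 4-chlorobenzyl group in place of the 4-bromobenzyl would give.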